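A fluoro step on the benzamido compound

The source may hold more compounds than are shown below. What is called first, only, known or untested is meant among the compounds shown, and "the series" means these compounds.

Compound 1 `COc1ccccc1NC(=O)Nc1ccc(Oc2ccnc3cc(OCCCCCCC(=O)NO)c(OC)cc23)cc1` gives 6280 nM in a functional assay on MCF7 cells (Homo sapiens) for antiproliferative activity, read by MTT assay; a lower number here means a stronger inhibitor, a higher number a weaker inhibitor
Compound 2 `COc1cc2c(Oc3ccc(NC(=O)NNC(=O)c4ccccc4)cc3)ccnc2cc1OCCCCCCC(=O)NO` gives 2450 nM in this assay

Among the compounds with values here, of these two, compound 2 holds the lower number, 2450 nM, and is the stronger inhibitor in this assay so far. Compound 3 `COc1cc2c(Oc3ccc(NC(=O)NNC(=O)c4ccccc4F)cc3)ccnc2cc1OCCCCCCC(=O)NO` differs from compound 2 by a single change (fluoro in place of hydrogen on an aromatic carbon) , namely fluoro in place of hydrogen on an aromatic carbon, ortho to a large group, so that phenyl becomes 2-fluorophenyl.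

Within the data shown here, only one measured step is available, and it bears on this change only loosely. That step, a 2.6-fold lower number from compound 1 to compound 2 (0.41 log units; beyond the scatter), put benzamido in place of 2-methoxyphenyl on an amide-type nitrogen, and it was modest though beyond the scatter. Among the measured compounds shown here, it exchanged a whole group, whereas compound 3 adds one fluoro atom, and no measured pair shows what fluoro does. No step beyond the scatter is therefore expected in this assay, and no direction can be firmly expected. The estimated step is a 1.1-fold lower number from compound 2 to compound 3 (0.05 log units; within the scatter) and it stays small. For compound 3 the estimated value is 2200 nM, with an expected range from 1000 nM to 4800 nM at its upper end.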

Compound 3, half-maximal inhibitory concentration: 3600 nM
Compound 3: middle estimate off by 1.6-fold (0.21 log units), on the low side; measured number inside the range.
By their numbers in this assay, from the lowest: compounds 2, 3 and 1 (each within the scatter of the next, the first and the last beyond it).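

Within the data shown here, the fluoro atom placed ortho to a large group, which turns phenyl into 2-fluorophenyl, gives a 1.5-fold higher number from compound 2 to compound 3 (0.17 log units; within the scatter) in this assay, so this single-atom change on the benzamido compound produces no step that can be told from the scatter. Set against the 2-methoxyphenyl compound, the ((2-fluorophenyl)carbonyl)amino group gives a 1.7-fold lower number from compound 1 to compound 3 (0.24 log units; within the scatter) and again stays within the scatter, which leaves compound 3 inseparable from both of its neighbours, even though compound 1 and compound 2 themselves stand apart by a 2.6-fold lower number from compound 1 to compound 2 (0.41 log units; beyond the scatter) in the same read-out. Nothing further is available that could account for these numbers, and no accompanying measurement speaks to what the fluoro atom does in this series.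

Going by these compounds, whether a chloro, a methoxy or a trifluoromethyl group on the same aromatic carbon would give a step beyond the scatter remains open, since a single fluoro atom cannot show how this place responds to larger groups. On these data alone, it is also open whether a longer chain on the shared core, or an amine on the terminal phenyl ring, would move the number in this assay further than any step seen here.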